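Second Fluoro on the Phenoxy Ring of Compound 1

This account rests on a few compounds, and the source may have more. Where it says the series, first, only, none or still open, it means among the compounds named here.

Compound 1 `CC(=O)N1CCCn2nc(COc3cccc(F)c3)cc21` was tested in a functional assay on HEK293 cells for positive allosteric modulation of metabotropic glutamate receptor 5 (Homo sapiens), read by calcium flux (on this read-out higher numbers stand for larger maximal responses and lower numbers for smaller maximal responses), and gave 58%. Its companion, compound 2 `CC(=O)N1CCCn2nc(COc3ccc(F)cc3)cc21`, gave 56% in this assay. Within the data shown here, the only measured step, a number 2 percentage points lower from compound 1 to compound 2 (within the scatter), stays within the scatter, so compound 1 and compound 2 cannot be told apart on these numbers; compound 1 merely has the higher of two values that the scatter treats as equal.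

Compound 3 `CC(=O)N1CCCn2nc(COc3cc(F)cc(F)c3)cc21` is not yet measured. It differs from compound 1 by fluoro in place of hydrogen on an aromatic carbon. Among the measured compounds shown here, the one step that bears on this change is a number 2 percentage points lower from compound 1 to compound 2 (within the scatter), which shows that moving the fluoro group around the ring left the response essentially unchanged. Adding a second fluoro is a different kind of change, and nothing measured here speaks directly to it, so the expectation is a step of no size beyond the scatter.

Compound 3 is therefore estimated at 58%, with a range from 44% to 72%, which is expected to correspond to no change at the digits printed from compound 1 to compound 3 (within the scatter).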

Compound 3, largest response reached (reported as percent of maximum), in percent of the reference or control that the assay uses: 63%
Compound 3: middle estimate off by 5 percentage points, on the low side; low and high end bracket the measured number.
By their numbers in this assay, from the lowest: compounds 2, 1 and 3 (each within the scatter of the next).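

In this assay, fluoro in place of hydrogen on an aromatic carbon, meta to a fluoro group, gives a number 5 percentage points higher from compound 1 to compound 3 (within the scatter) and so does not separate compound 3 from compound 1. The earlier step only moved a single fluoro around the ring, whereas this one adds a heavy atom, and the second fluoro is tolerated here without a response that can be told apart from that of compound 1. Nothing measured here accounts for this result.

Going by these compounds, it remains open whether a larger group at this position, such as chloro, methoxy or trifluoromethyl, would give a step beyond the scatter. Also open, on these data alone, is how the response would follow a change away from the phenoxy ring, such as a propionyl or a methanesulfonyl group in place of the acetyl group on the shared core.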